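The compounds below may be only part of what the source reports. "The series", "measured", "known", "first", "only" and "open" are said of these compounds alone.

Measured so far in an assay for inhibition of epoxide hydrolase 1 (Homo sapiens), read by fluorescence, using microsomes; a higher number here means a weaker inhibitor, a lower number a stronger inhibitor: compound 1 `CC(=O)NC(=S)Nc1ccc(Br)cc1` gives 1640 nM; compound 2 `CCOc1ccc(OCC)c(NC(=S)NC(=O)c2ccccc2)c1` gives 2040 nM; compound 3 `O=C(NC(=S)Nc1ccc(Br)cc1)c1ccccc1` gives 3440 nM.

Compound 3 and compound 1 differ in one place, (methyl in place of phenyl on a carbonyl carbon), and in this assay this gives a 2.1-fold lower number from compound 3 to compound 1 (0.32 log units; beyond the scatter). Compound 2 stands close to compound 1, and its difference from compound 3 is within the scatter; how the core of compound 2 differs from that of compound 3 is not broken down here.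

Compound 4 `CCOc1ccc(OCC)c(NC(=S)NC(C)=O)c1` is not yet measured. It differs from compound 2 by methyl in place of phenyl on a carbonyl carbon, the same change as from compound 3 to compound 1, at the same kind of carbonyl carbon. Resting on a 2.1-fold lower number from compound 3 to compound 1 (0.32 log units; beyond the scatter), compound 4 is expected to show a step of a 2.1-fold lower number from compound 2 to compound 4 (0.32 log units; beyond the scatter) in this assay. Compound 4 is therefore estimated at 970 nM, with a likely range from 400 nM to 2400 nM.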

Compound 4, half-maximal inhibitory concentration: 2530 nM
For compound 4 the middle estimate is 2.6-fold (0.42 log units) below the measured one; measured number above the stated range.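

In this assay, methyl in place of phenyl on a carbonyl carbon gives a 1.2-fold higher number from compound 2 to compound 4 (0.09 log units; within the scatter), so on this core the change leaves the number within the scatter. Set beside the earlier step, this one cannot be said to differ from it: the same change on two cores in this assay, a 2.1-fold lower number (0.32 log units; beyond the scatter) from compound 3 to compound 1 and a 1.2-fold higher number (0.09 log units; within the scatter) from compound 2 to compound 4, 2.6-fold (0.42 log units) apart, within the scatter of two such steps. For the compounds shown here, this shows that the two results are compatible with one modest effect of the change or with none, but it does not show that the step carries over reliably, since only two pairs are available and just one of them lies beyond the scatter.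

The compounds shown leave open how a longer chain, such as propyl, or an amine would read on this carbonyl carbon. They also leave open how the change would read on a third core.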